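A few compounds are considered here, and "the series" means these few. Any claim that something is new, unique, unknown or untested is made for them only; others in the source may bear on it.

The study sets three measured compounds beside one that awaits measurement. Compound 1 `COc1ccc(-c2ncnc3c2ncn3C[C@@H]2C[C@H](CO)c3ccccc32)cc1` gives 17600 nM in an ADME assay on L1210/0 cells (Mus musculus) for cytotoxicity, with a stated time of 48 h; on this read-out higher numbers stand for weaker inhibition and lower numbers for stronger inhibition. Compound 2 `OC[C@H]1C[C@@H](Cn2cnc3c(-c4ccccc4)ncnc32)c2ccccc21` gives 28100 nM. Compound 3 `CC1(C)[C@@H](Cn2nnc3c(Cl)nc(N)nc32)CC[C@@]1(C)CO` gives 44600 nM, the highest of the three numbers; against compound 2 it lies within the scatter, while against compound 1 the gap is beyond it. Among the measured compounds shown here, the one measured step, a 1.6-fold higher number from compound 1 to compound 2 (0.20 log units; within the scatter), concerns hydrogen in place of methoxy on the core of compound 1, a core unlike that of compound 3, and so does not bear on the change under consideration. Compound 4 `CC1(C)[C@@H](Cn2nnc3c(N)nc(N)nc32)CC[C@@]1(C)CO` differs from compound 3 by amino in place of chloro on an aromatic carbon. For the measured compounds named here, no measured step speaks to this change, so nothing in the data points to a movement in either direction; compound 4 is therefore expected to show no change at the digits printed from compound 3 to compound 4 (within the scatter), no step beyond the scatter. On that basis compound 4 is estimated at 44600 nM, with a range from 15000 nM to 130000 nM.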

Compound 4, half-maximal inhibitory concentration: > 200000 nM
Compound 4: only a limit was reported; the forecaster's own chance of this, stated with the estimate: 25%; middle value at least 4.4-fold (0.65 log units) away from the limit.
By their numbers in this assay, from the lowest: compounds 1, 2 and 3 (each within the scatter of the next, the first and the last beyond it). At a limit, above all of these: compound 4.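

In this assay, amino in place of chloro on this aromatic carbon, next to the ring nitrogen, gives an at least 4.4-fold higher number from compound 3 to compound 4 (0.65 log units; beyond the scatter). This is the first change at this position in the compounds shown, and unlike the one earlier step, made on the core of compound 1, it lies beyond the scatter. Compound 4 is reported only as a limit and not as a number, so the step gives a floor on the size of the change and not the size itself: the limit of > 200000 nM in this assay, at which 1 of the 4 values shown sits.

The compounds shown leave open whether a hydrogen, a methyl or a methylamino group at this position would stay near compound 3 or move towards compound 4. They also leave open whether the same exchange of chloro for amino would shift the number on the core of compound 1.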